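A few compounds are considered here, and "the series" means these few. Any claim that something is new, unique, unknown or untested is made for them only; others in the source may bear on it.

Of the compounds shown here, three built on one shared core have been measured in a functional assay on BJAB cells (Homo sapiens) for antiproliferative activity, with a stated time of 4 days; a lower number here means that less compound is needed, a higher number that more compound is needed for the effect. Compound 1 `CCSc1sc(-n2nc(C)c(Cc3ccccc3[N+](=O)[O-])c2C(=O)O)nc1-c1ccc(Cl)c(Cl)c1` gives 59000 nM in this assay. Compound 2 `Cc1c(-c2cc(Cl)cc(Cl)c2)c(C(=O)O)nn1-c1nc(-c2cc(Cl)cc(Cl)c2)c(SC(C)C)s1` gives 2000 nM in this assay. Compound 3 `CC(=O)Nc1ccc(-c2c(C)nn(-c3nc(-c4ccc(Cl)c(Cl)c4)c(SC(C)C)s3)c2C(=O)O)cc1` gives 139000 nM in this assay, the highest number of the three: compound 1 stands nearest and compound 2 furthest, and both gaps lie beyond the usual scatter, so compound 3 needs the most material of the three for the same effect.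

Compound 4 `Cc1nn(-c2nc(-c3ccc(Cl)c(Cl)c3)c(SC(C)C)s2)c(C(=O)O)c1-c1cncc(C#N)c1` has not yet been measured. It differs from compound 3 in one place: 5-cyanopyridin-3-yl in place of 4-acetamidophenyl on an aromatic carbon. Among the compounds with values here, no two measured compounds differ in only one place, so no measured step shows what such a swap does here. Compound 2, which carries a different aryl group on the shared core, gives 2000 nM, while compound 3 gives 139000 nM. The expected step is a 3.5-fold lower number from compound 3 to compound 4 (0.54 log units; beyond the scatter), a modest move toward a lower number, with wide uncertainty. Compound 4 is expected to give 40000 nM in this assay, between 8000 nM and 200000 nM.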

Compound 4, half-maximal effective concentration: 20000 nM
Beside the measured number, compound 4's estimate is 2.0-fold (0.30 log units) above it; the measured number falls inside the stated range.
By their numbers in this assay, from the lowest: compound 2; then compound 4; then compound 1; then compound 3.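

In this assay, putting 5-cyanopyridin-3-yl in place of 4-acetamidophenyl on this aromatic carbon gives a 7.0-fold lower number from compound 3 to compound 4 (0.84 log units; beyond the scatter). Within the data shown here, this is the first step that changes one place only, and it shows that the number responds to the aryl group held at this position, though the step is modest. The swap alters several things together, replacing a carbon-only ring with one holding a hetero atom, exchanging the acetamide for a nitrile and removing the hydrogen-bond donor, and nothing measured here explains the shift.

From the compounds shown here alone, it remains open whether the ring nitrogen or the nitrile carries the step, which a pyridin-3-yl without the nitrile or a 3-cyanophenyl would help separate. Also open, going by these compounds, is what a 4-aminophenyl would do at this position.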